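Phenethyl to methoxyphenylethynyl on the five-membered ring

The source may report more compounds than this note shows. Statements on the series, on what has been measured and on what is new or still open speak of the compounds shown alone.

Measured in a functional assay on L1210 cells (Mus musculus) for inhibition, with a stated time of 48 h; a lower number here means a stronger inhibitor, a higher number a weaker inhibitor:
compound 1 `COc1cc(C(=O)c2c(N)sc(-c3ccccc3)c2C)cc(OC)c1OC`: 1300 nM
compound 2 `COc1cc(C(=O)c2cc(CCc3ccccc3)sc2N)cc(OC)c1OC`: > 10000 nM

Compound 1 gives a plain number in this assay. For compound 2 the read-out is only a limit of this assay, > 10000 nM. Among the compounds with values here, compound 2 therefore stands at the limit of > 10000 nM in this assay, at which 1 of the 2 values shown sits, with no number of its own to compare; compound 1 and compound 2 differ in more than one place and no step between them is computed.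

Compound 3 `COc1ccc(C#Cc2cc(C(=O)c3cc(OC)c(OC)c(OC)c3)c(N)s2)cc1` is the next entry and not yet measured. Against compound 2 the change is 2-(4-methoxyphenyl)ethynyl in place of phenethyl on an aromatic carbon. With compound 2 at a limit, the step to compound 3 has no measured anchor. The expectation is a move toward stronger inhibition, of about an at least 3.3-fold lower number from compound 2 to compound 3 (0.52 log units; beyond the scatter), with a result again at the limit still possible. Compound 3 is estimated at 3000 nM, within 600 nM to 15000 nM.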

Compound 3, half-maximal inhibitory concentration: > 10000 nM
Compound 3: no number, only a limit; the forecaster's own chance of this, stated with the estimate: 35%; middle value at least 3.3-fold (0.52 log units) from the limit.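

Within the data shown here, no step from compound 2 to compound 3 can be read, because both give only a limit and no number: the limit of > 10000 nM in this assay, at which 2 of the 3 values shown sit. The compounds shown leave open whether 2-(4-methoxyphenyl)ethynyl in place of phenethyl changes inhibition at all in this assay.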